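The source may report more compounds than this note shows. Statements on the series, on what has been measured and on what is new or still open speak of the compounds shown alone.

The series rests on a shared core that bears a substituted phenylurea, and it is followed in a functional assay on MDA-MB-231 cells (Homo sapiens) for cytotoxicity, read by MTT assay, with a stated time of 72 h; a higher number here means a weaker inhibitor, a lower number a stronger inhibitor. Compound 1 `CN(C)CCNc1nc(-c2ccc(NC(=O)Nc3ccccc3Cl)cc2)nc2ccsc12` gives 550 nM in this assay. Compound 2 `CN(C)CCNc1nc(-c2ccc(NC(=O)Nc3ccc(Cl)cc3Cl)cc2)nc2ccsc12` differs from it by chloro in place of hydrogen on an aromatic carbon, and in this assay compound 2 gives 2450 nM. That change produced a 4.5-fold higher number from compound 1 to compound 2 (0.65 log units; beyond the scatter). Compound 3 `CCN(CC)CCCNc1nc(-c2ccc(NC(=O)Nc3ccccc3Cl)cc2)nc2c(Cl)c(Cl)sc12` carries a different core from compound 1; the difference between the two cores is not broken down here. In this assay compound 3 gives 970 nM, a number that sits close to that of compound 1 and apart from that of compound 2.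

Compound 4 `CCN(CC)CCCNc1nc(-c2ccc(NC(=O)Nc3ccc(Cl)cc3Cl)cc2)nc2c(Cl)c(Cl)sc12` has not yet been measured. It differs from compound 3 by chloro in place of hydrogen on an aromatic carbon, and the place of the change is described in the same words as for the change from compound 1 to compound 2, so it is the same change made on the core of compound 3. For compound 4 in this assay a step of roughly the same size is expected, namely a 4.4-fold higher number from compound 3 to compound 4 (0.65 log units; beyond the scatter), because compound 1 to compound 2 showed a 4.5-fold higher number from compound 1 to compound 2 (0.65 log units; beyond the scatter) for the same change. Within the data shown here, on that basis compound 4 is estimated at 4300 nM in this assay, with a range from 1600 nM to 11000 nM to allow for the one prior example being the only guide.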

Compound 4, half-maximal inhibitory concentration: 3940 nM
Compound 4: the middle estimate sits 1.1-fold (0.04 log units) above what was measured; measured number inside the range.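

On the core of compound 3, the change from 2-chlorophenyl to 2,4-dichlorophenyl gave a 4.1-fold higher number from compound 3 to compound 4 (0.61 log units; beyond the scatter) in this assay, the same direction as the step already seen on the core of compound 1. Among these compounds, the size of the step therefore carried over between the two cores, and the two steps cannot be told apart: the same change on two cores in this assay, a 4.5-fold higher number (0.65 log units; beyond the scatter) from compound 1 to compound 2 and a 4.1-fold higher number (0.61 log units; beyond the scatter) from compound 3 to compound 4, 1.1-fold (0.04 log units) apart, within the scatter of two such steps This shows only that the change behaved alike on these two cores in this one assay; with just two pairs, both starting from a 2-chlorophenyl urea, it does not establish a general rule for the series, and it gives no reason why the number rises.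

The compounds shown leave open whether a fluoro, methyl or methoxy group entering at the same place would give a step of similar size, and whether the step would survive if the 2-chlorophenyl group were replaced by an unsubstituted phenyl group. Among the compounds shown here, they also leave open how much each part of the difference between the two cores contributes, since no single-place step separates those parts, and whether the step would carry over to a third core.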